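The source may hold more compounds than are shown below. What is called first, only, known or untested is meant among the compounds shown, and "the series" means these compounds.

Of the compounds shown here, two have been tested in an assay on isolated protein for displacement of a labelled ligand from metabotropic glutamate receptor 5 (Rattus norvegicus) (on this read-out lower numbers stand for stronger inhibition and higher numbers for weaker inhibition), and neither gave a number. Compound 1 `O=C(Nc1ccccc1)O/N=C(\C1CCCCC1)C(CN1CCN(c2ccccc2)CC1)C1CCCCC1` returned only a limit, > 1000 nM. Compound 2 `Cc1nccn1CC(/C(=N/OC(=O)Nc1cccc(Cl)c1)C1CCCCC1)C1CCCCC1` likewise returned only a limit in this assay, > 1000 nM. Among the measured compounds shown here, because of the limit of > 1000 nM in this assay, at which 2 of the 2 values shown sit, no measured step exists from which a direction could be read. Compound 3 `O=C(Nc1cccc(Cl)c1)O/N=C(\C1CCCCC1)C(Cc1cc[nH]c1)C1CCCCC1` is not yet measured. It differs from compound 2 by 1H-pyrrol-3-yl in place of 2-methyl-1H-imidazol-1-yl on a saturated chain carbon, two bonds along the chain from a carbon with a double bond to nitrogen and a saturated ring carbon. With both measured values sitting at the limit, the expected step from compound 2 to compound 3 in this assay is a step that the limit leaves unreadable from compound 2 to compound 3, and nothing beyond the scatter is anticipated. Compound 3 is accordingly estimated at 1500 nM in this assay, within a range from 300 nM to 8000 nM.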

Compound 3, inhibition constant: 16.1 nM
Compound 3: the middle estimate sits 93-fold (1.97 log units) above what was measured; the measured number lies below the stated range.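

In this assay, the group on the saturated chain carbon proves decisive: 1H-pyrrol-3-yl in place of 2-methyl-1H-imidazol-1-yl gives an at least 62-fold lower number from compound 2 to compound 3 (1.79 log units; beyond the scatter). Compound 3, at 16.1 nM, is the only compound shown with an actual number, so this series can bind measurably once this group is present. The step is a minimum rather than an exact size because compound 2 has only a limit: the limit of > 1000 nM in this assay, at which 2 of the 3 values shown sit.

The change swaps the ring, removes the methyl and alters the counts, going from 0 to 1 hydrogen-bond donor and from 2 to 0 hydrogen-bond acceptors, and the compounds shown cannot separate these differences. Going by these compounds, it remains open whether an unsubstituted 1H-imidazol-1-yl or a 1H-pyrrol-1-yl, whose ring nitrogen carries no hydrogen, would give a number like that of compound 3.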